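From Methoxy to Bromo on a Shared Core

The source may report more compounds than this note shows. Statements on the series, on what has been measured and on what is new or still open speak of the compounds shown alone.

In a functional assay on HepG2 cells (Homo sapiens) for antiproliferative activity, read by MTT assay, with a stated time of 72 h (on this read-out lower numbers stand for stronger inhibition and higher numbers for weaker inhibition), three compounds have been measured so far. Compound 1, `COc1ccc(NC(=S)Nc2nc(C(=O)NCCCc3ccccc3)cs2)cc1`, gives 71300 nM, and compound 2, `CCOC(=O)c1csc2nc(CN3CCN(C)CC3)c(-c3ccc(OC)cc3)n12`, gives 68400 nM. Compound 3, `CCOC(=O)c1csc2nc(CN3CCN(Cc4ccccc4)CC3)c(-c3ccc(OC)cc3)n12`, gives 26400 nM, the lowest of the three numbers and beyond the scatter of the other two.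

Among the measured compounds shown here, the one measured step between close relatives is a 2.6-fold lower number from compound 2 to compound 3 (0.41 log units; beyond the scatter), a modest change that puts phenyl in place of hydrogen on a saturated chain carbon bound to an amine nitrogen in a ring.

Compound 4, `CCOC(=O)c1csc2nc(CN3CCN(Cc4ccccc4)CC3)c(-c3ccc(Br)cc3)n12`, departs from compound 3 in a single place: bromo in place of methoxy on an aromatic carbon. This swap turns 4-methoxyphenyl into 4-bromophenyl.

For the measured compounds named here, the measured step lies at another place in the structure, and no measured pair shows this swap, so the data offer no direct guide to its size or direction. The expectation therefore starts from compound 3 at 26400 nM, with no step beyond the scatter foreseen. The expected change is a 1.3-fold lower number from compound 3 to compound 4 (0.10 log units; within the scatter). For compound 4, the estimated value is 21000 nM, with an expected range from 8000 nM to 55000 nM.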

Compound 4, half-maximal inhibitory concentration: 47300 nM
Beside the measured number, compound 4's estimate is 2.3-fold (0.35 log units) below it; measured number inside the range.
By their numbers in this assay, from the lowest: compounds 3, 4, 2 and 1 (each within the scatter of the next, the first and the last beyond it).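

In this assay, among the compounds shown here, bromo in place of methoxy on the aromatic carbon gives a 1.8-fold higher number from compound 3 to compound 4 (0.25 log units; within the scatter), the first reading at this place, as the only earlier step lay elsewhere in the structure. On this one pair, the position takes the exchange of methoxy, with 2 heavy atoms and 1 hydrogen-bond acceptor, for bromo, with 1 heavy atom and 0 hydrogen-bond acceptors, without a step beyond the scatter. No supporting measurement bears on this result, so the data give no account of it.

The compounds shown leave open whether other groups on the same aromatic carbon, such as an amine, a nitrile or a carboxylic acid, would give a step beyond the scatter, or whether a bare hydrogen there would stay within it. They also leave open whether the same swap would give a step of like size on compound 2, and whether one pair at this position can speak for the shared core as a whole.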